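Swapping a Sulfonamide for a Phenyl Sulfone

This account rests on a few compounds, and the source may have more. Where it says the series, first, only, none or still open, it means among the compounds named here.

Measured compounds:
compound 1 `NS(=O)(=O)c1ccc(NC(=O)NCc2ccncc2)cc1` gives 14300 nM
compound 2 `CCOC(=O)c1ccc(N/C(=N\C#N)NCc2ccncc2)cc1` gives 41400 nM
compound 3 `CCOC(=O)c1ccc(NC(=O)N(C)Cc2ccncc2)cc1` gives a limit of > 100000 nM

The read-out throughout is an assay on isolated protein for activation of Nicotinamide phosphoribosyltransferase (Homo sapiens); a lower number here means that less compound is needed, a higher number that more compound is needed for the effect. Among the two compounds with a number, compound 1 has the lower one, and compound 2 stands well beyond the scatter above it. Compound 3 has only a limit, not a number; of the three values, one sits at the limit of > 100000 nM in this assay, at which 1 of the 3 values shown sits.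

Compound 4 `O=C(NCc1ccncc1)Nc1ccc(S(=O)(=O)c2ccccc2)cc1` is the compound still to be measured. It differs from compound 1 in one place: phenyl in place of amino on a sulfonyl sulfur. Among the measured compounds shown here, no pair among the measured compounds differs in a single place, so no step of the same kind has been measured. The urea of compound 1 gives the lowest of the numbers shown, and the shared core is otherwise untouched, so no more than a modest shift is expected in this assay, in either direction. Compound 4 is expected to give 8000 nM, within 1500 nM to 40000 nM; this estimated result means a step of a 1.8-fold lower number from compound 1 to compound 4 (0.25 log units; within the scatter).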

Compound 4, half-maximal effective concentration: 85 nM
Compound 4: middle estimate off by 94-fold (1.97 log units), on the high side; the whole stated range lies above it.
By their numbers in this assay, from the lowest: compound 4; then compound 1; then compound 2. At a limit, above all of these: compound 3.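

Placing phenyl in place of amino on a sulfonyl sulfur gives a 170-fold lower number from compound 1 to compound 4 (2.23 log units; beyond the scatter) in this assay, so this position, which no earlier pair could probe, has a strong bearing on the number. The amino group and its hydrogen-bond donor give way to a larger aromatic ring of carbon only, and the number still falls, so in this pair the larger group is clearly accepted on the sulfur. Nothing measured here explains why the step is so large.

On these data alone, it remains open whether the ring itself matters or simply the loss of the amino group, and a methyl or a cyclohexyl on the same sulfur would help separate the two. Also open, as far as these compounds go, is whether a fluorine or a methoxy group on the new phenyl ring would move the number further.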